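Toward compound 3: a naphthalenyl ester on the shared core

The source may report more compounds than this note shows. Statements on the series, on what has been measured and on what is new or still open speak of the compounds shown alone.

Measured so far:
- compound 1, `CC1=NC(C)=C(C(=O)O)C(c2cccc(Cl)c2)/C1=C(\O)OC/C=C/c1ccccc1`: 1000 nM
- compound 2, `CC1=NC(C)=C(C(=O)O)C(c2cccc(Cl)c2)/C1=C(\O)OCC(=O)Nc1ccccc1`: 28000 nM

In a functional assay on IMR-32 cells for inhibition of Voltage-dependent N-type calcium channel subunit alpha-1B (Homo sapiens), read by calcium flux (a lower number here means a stronger inhibitor, a higher number a weaker inhibitor), compound 2 gives the highest of the two numbers; its nearest neighbour is compound 1, and the step of a 28-fold higher number from compound 1 to compound 2 (1.45 log units; beyond the scatter) was large and beyond the scatter. Compound 3, `CC1=NC(C)=C(C(=O)O)C(c2cccc(Cl)c2)/C1=C(\O)OCc1ccc2ccccc2c1`, has not yet been measured. It differs from compound 2 in one place: naphthalen-2-yl in place of phenylcarbamoyl on a saturated chain carbon bound to an oxygen on an unsaturated carbon. Among the compounds with values here, the only measured step that bears on this change is the one from compound 1 to compound 2, where an aromatic hydrocarbon group on that chain carbon gave way to the phenylcarbamoyl group and the number rose sharply. Compound 3 restores an aromatic hydrocarbon group there, so the step of a 14-fold lower number from compound 2 to compound 3 (1.15 log units; beyond the scatter) is expected to run the opposite way. Compound 3 is therefore estimated at 2000 nM in this assay, within a range of 500 nM to 8000 nM.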

Compound 3, half-maximal inhibitory concentration: 1000 nM
Estimate against measurement, compound 3: 2.0-fold (0.30 log units) above; the measured number falls inside the stated range.
By their numbers in this assay, from the lowest: compounds 1 and 3 (each within the scatter of the next); then compound 2.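

In this assay, naphthalen-2-yl in place of phenylcarbamoyl gave a 28-fold lower number from compound 2 to compound 3 (1.45 log units; beyond the scatter) on this saturated chain carbon, so the high number of compound 2 is not a fixed feature of the shared core. Naphthalen-2-yl in place of 2-phenylethenyl gave no change at the digits printed from compound 1 to compound 3 (within the scatter) here, so two different aromatic hydrocarbon groups at this place read alike, with two aromatic rings in one and a double bond and one ring in the other. Nothing available explains why compound 2 stands apart from compound 1 and compound 3.

The compounds shown leave open whether a saturated group such as cyclohexyl at this place would read like compound 1 and compound 3 or like compound 2. They also leave open whether an amine or a carboxylic acid on the chain would behave as phenylcarbamoyl does.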